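A few compounds are considered here, and "the series" means these few. Any claim that something is new, unique, unknown or untested is made for them only; others in the source may bear on it.

Measured in an in vitro ADME assay on microsomes from liver (Homo sapiens) for metabolic stability; a lower number here means slower removal, a higher number faster removal of the compound:
- compound 1 `CC[C@H](C)[C@@H]1C(=O)N[C@H](C2Cc3ccccc3C2)C(=O)N1[C@@H](C(=O)N1CCOCC1)c1cnc(C)cc1C`: 1 mL.min-1.g-1
- compound 2 `CC[C@H](C)[C@@H]1C(=O)N[C@H](C2Cc3ccccc3C2)C(=O)N1[C@@H](C(=O)N(C)C)c1cnc(C)cc1C`: 9 mL.min-1.g-1
- compound 3 `CC[C@H](C)[C@@H]1C(=O)N[C@H](C2Cc3ccccc3C2)C(=O)N1[C@@H](C(=O)NC)c1cc(C)cnc1C`: 3 mL.min-1.g-1

Compound 3, at 3 mL.min-1.g-1, holds the middle place of the three numbers, higher than compound 1 and lower than compound 2, and both gaps lie beyond the scatter. Compound 4 `CC[C@H](C)[C@@H]1C(=O)N[C@H](C2Cc3ccccc3C2)C(=O)N1[C@@H](C(=O)NC)c1cnc(C)cc1C` keeps the amide of compound 3 and exchanges one group: 4,6-dimethylpyridin-3-yl in place of 2,5-dimethylpyridin-3-yl on a saturated chain carbon bound to an amide-type nitrogen in a ring and a carbonyl carbon. In words, this is 4,6-dimethylpyridin-3-yl in place of 2,5-dimethylpyridin-3-yl on a saturated chain carbon bound to an amide-type nitrogen in a ring and a carbonyl carbon.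

Among the compounds with values here, no measured step covers this exchange. Within the data shown here, the only step available, a 9.0-fold higher number from compound 1 to compound 2 (0.95 log units; beyond the scatter), is dimethylamino in place of morpholin-4-yl on a carbonyl carbon, with 4,6-dimethylpyridin-3-yl present on both sides. It shows that a change at the amide can move the number beyond the scatter, but it gives no size for the exchange at hand. Compound 4 shares its amide with neither compound 1 nor compound 2, so compound 3 remains the closest anchor in this assay. No step beyond the scatter is therefore expected, and the direction is open. The estimated step is a 1.3-fold higher number from compound 3 to compound 4 (0.12 log units; within the scatter). The expected value for compound 4 is 4 mL.min-1.g-1, with an estimated range of 1.5 mL.min-1.g-1 to 10 mL.min-1.g-1.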

Compound 4, intrinsic clearance in microsomes: 7 mL.min-1.g-1
Estimate against measurement, compound 4: 1.8-fold (0.24 log units) below; the range from low to high includes it.
By their numbers in this assay, from the lowest: compound 1; then compound 3; then compounds 4 and 2 (each within the scatter of the next).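

In this assay, within the data shown here, the exchange of 2,5-dimethylpyridin-3-yl for 4,6-dimethylpyridin-3-yl with the methylamide held constant gives a 2.3-fold higher number from compound 3 to compound 4 (0.37 log units; beyond the scatter), the first evidence that the pyridine isomer on this saturated chain carbon can itself move the number beyond the scatter, as compounds 1 and 2 carry the same pyridine and could not show this. With 4,6-dimethylpyridin-3-yl in place, removing one methyl from the amide-type nitrogen gives a 1.3-fold lower number from compound 2 to compound 4 (0.11 log units; within the scatter), within the scatter, whereas methylamino in place of morpholin-4-yl gives a 7.0-fold higher number from compound 1 to compound 4 (0.85 log units; beyond the scatter), so among these three amides, morpholin-4-yl alone stands apart, in line with a 9.0-fold higher number from compound 1 to compound 2 (0.95 log units; beyond the scatter). No measurement available here accounts for either the pyridine step or the amide steps.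

The compounds shown leave open whether the morpholin-4-yl amide keeps its low number with 2,5-dimethylpyridin-3-yl, and so whether the pyridine and amide steps add up or depend on each other. Also open, from the compounds shown here alone, is where a piperidin-1-yl amide or an unsubstituted primary amide would fall, and whether a methoxy group in place of a pyridine methyl would shift the number.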